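A chloro in place of the aryloxy: compound 3

The source may hold more compounds than are shown below. What is called first, only, known or untested is meant among the compounds shown, and "the series" means these compounds.

Compound 1, `Cc1nnsc1CO/N=C/c1c(C)nn(C)c1Oc1ccc(I)cc1`, in a functional assay on PANC-1 cells (Homo sapiens) for inhibition, read by MTT assay, with a stated time of 48 h (a higher number here means a weaker inhibitor, a lower number a stronger inhibitor), gives > 50000 nM, which is a limit of the assay and not a number.
Compound 2, `Cc1nnsc1CO/N=C/c1c(C)nn(C)c1Oc1cccc(F)c1F`, in this assay gives 12200 nM.

Compound 1 stands only at a limit in this assay, as the limit of > 50000 nM in this assay, at which 1 of the 2 values shown sits, shows, so no number is known for it. Compound 3, `Cc1nnsc1CO/N=C/c1c(C)nn(C)c1Cl`, differs from compound 1 by chloro in place of 4-iodophenoxy on an aromatic carbon. Among the compounds with values here, the only measured step, an at least 4.0-fold lower number from compound 1 to compound 2 (0.61 log units; beyond the scatter), exchanges one aryl group for another on the same oxygen and does not remove the aryloxy altogether, so it bears on this change only loosely. With the aryloxy gone and the limit of compound 1 as the starting point, compound 3 is expected to remain weak in this assay, with the step that the limit leaves unreadable from compound 1 to compound 3 most likely not beyond the scatter. The estimate for compound 3 is 60000 nM, within 15000 nM to 200000 nM.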

Compound 3, half-maximal inhibitory concentration: 26600 nM
The estimate for compound 3 lay 2.3-fold (0.35 log units) above the measured number; low and high end bracket the measured number.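

At this position, the aromatic ring of the aryloxy is not needed for a measurable number in this assay: with a single chloro in place of 4-iodophenoxy, compound 3 gives 26600 nM. The change amounts to an at least 1.8-fold lower number from compound 1 to compound 3 (0.27 log units; that floor lies within the scatter), so these values alone do not establish a real gain from removing the 4-iodophenoxy. Compound 1 stands at a limit and not a number, and the true size of this step stays unknown: the limit of > 50000 nM in this assay, at which 1 of the 3 values shown sits.

The compounds shown leave open whether an amine, a methoxy or a longer chain at this position would give a lower number than the chloro does. They also leave open how much of the difference among the aryloxy compounds would carry over to other aryl groups on the same oxygen.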